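The source may report more compounds than this note shows. Statements on the series, on what has been measured and on what is new or still open speak of the compounds shown alone.

Of the compounds shown here, two have so far been measured in an assay on HEK293 cells for agonist activity at Toll-like receptor 8 (Homo sapiens), read by a luciferase reporter, with a stated time of 6 h; on this read-out higher numbers stand for an effect only at larger amounts of compound and lower numbers for an effect already at smaller amounts. Compound 1 `CCCCNc1nc(N)nc2c1CN(Cc1ccccc1)CC2` gives 0.06 uM and stands lowest of the two numbers. Compound 2 `CCCCNc1nc(N)nc2c1CCN(Cc1ccccc1)C2` gives 0.4 uM, and the gap between the two values lies beyond the usual scatter of repeated runs. Compound 3 `CCCCNc1nc(N)nc2c1CN(Cc1cccnc1)CC2` has not yet been measured in this assay. It differs from compound 1 in a single place: pyridin-3-yl in place of phenyl on a saturated chain carbon bound to an amine nitrogen in a ring. For the measured compounds named here, no measured pair in this set carries that change, so the step can only be anticipated, not read from earlier data. For compound 3 the step of a 1.7-fold higher number from compound 1 to compound 3 (0.22 log units; within the scatter) is expected to be small, a modest upward movement of the number that may well remain within the scatter. Compound 3 is accordingly estimated to give 0.1 uM, with a range from 0.03 uM to 0.4 uM in this assay.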

Compound 3, minimum effective concentration: 0.13 uM
For compound 3 the middle estimate is 1.3-fold (0.11 log units) below the measured one, and the stated range covers the measured number.
By their numbers in this assay, from the lowest: compound 1; then compound 3; then compound 2.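

In this assay, replacing phenyl with pyridin-3-yl on a saturated chain carbon bound to an amine nitrogen in a ring gives a 2.2-fold higher number from compound 1 to compound 3 (0.34 log units; beyond the scatter), the first step read at this place. This modest step, just beyond the scatter, shows that the place tolerates a ring nitrogen and one added hydrogen-bond acceptor at an unchanged heavy-atom count, with a cost in the number but no collapse of the effect. Nothing measured here accounts for the rise.

The compounds shown leave open whether pyridin-2-yl or pyridin-4-yl would give the same step, and whether a ring carrying a methoxy group or a chlorine would lower the number instead. They also leave open whether the same exchange would move the number similarly on the core of compound 2.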